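Swapping the Side-Chain Ester for a Methoxybutyl Ether

This account rests on a few compounds, and the source may have more. Where it says the series, first, only, none or still open, it means among the compounds named here.

Of the compounds shown here, three built on one shared core have been measured in a functional assay on DU-145 cells (Homo sapiens) for cytotoxicity, read by MTT assay; a lower number here means a stronger inhibitor, a higher number a weaker inhibitor. Compound 1 `CCCC(O)CC(=O)O[C@H](CC=C(C)C)C1=CC(=O)c2c(O)ccc(O)c2C1=O` gives only a limit of the assay, > 100000 nM. Compound 2 `CC(C)=CC[C@@H](OC[C@@H](C)O)C1=CC(=O)c2c(O)ccc(O)c2C1=O` gives 14300 nM. Compound 3 `CC(C)=CC[C@@H](OC(=O)CC(C)(O)C(C)C)C1=CC(=O)c2c(O)ccc(O)c2C1=O` gives 16900 nM, the higher of the two numbers, yet the gap a 1.2-fold higher number from compound 2 to compound 3 (0.07 log units; within the scatter) keeps the two compounds indistinguishable. Both remaining steps, an at least 6.9-fold lower number from compound 1 to compound 2 (0.84 log units; beyond the scatter) and an at least 5.9-fold lower number from compound 1 to compound 3 (0.77 log units; beyond the scatter), are real, since each begins at a limit.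

Compound 4 `CCC(CO[C@H](CC=C(C)C)C1=CC(=O)c2c(O)ccc(O)c2C1=O)OC` differs from compound 3 in a single place: 2-methoxybutyl in place of (2-hydroxy-2,3-dimethylbutyl)carbonyl on an oxygen on a saturated carbon. The most telling comparison is a 1.2-fold higher number from compound 2 to compound 3 (0.07 log units; within the scatter), where an oxygen on a saturated carbon carried either 2-hydroxypropyl or (2-hydroxy-2,3-dimethylbutyl)carbonyl with no change beyond the scatter; the exchange of a carbonyl-bearing group for a plain chain thus left the number where it was. Moving from the (2-hydroxy-2,3-dimethylbutyl)carbonyl of compound 3 to 2-methoxybutyl is therefore expected to give a step of a 1.1-fold lower number from compound 3 to compound 4 (0.05 log units; within the scatter), nothing beyond the scatter. Compound 4 is estimated at 15000 nM, with a range from 5000 nM to 50000 nM.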

Compound 4, half-maximal inhibitory concentration: 45700 nM
Compound 4: the middle estimate sits 3.0-fold (0.48 log units) below what was measured; low and high end bracket the measured number.
By their numbers in this assay, from the lowest: compounds 2 and 3 (each within the scatter of the next); then compound 4. At a limit, above all of these: compound 1.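

In this assay, 2-hydroxypropyl and (2-hydroxy-2,3-dimethylbutyl)carbonyl had looked interchangeable on this oxygen, but 2-methoxybutyl does not fit with them, giving a 2.7-fold higher number from compound 3 to compound 4 (0.43 log units; beyond the scatter) and a 3.2-fold higher number from compound 2 to compound 4 (0.50 log units; beyond the scatter). The presence of a carbonyl therefore cannot be the whole story, as compound 2 and compound 4 both lack one in this group, while 2-methoxybutyl also has no hydrogen-bond donor, unlike the group it replaces in compound 3. Compound 4 still compares well with compound 1, with an at least 2.1-fold lower number from compound 1 to compound 4 (0.34 log units; beyond the scatter), but compound 1 gives only a limit of the assay, so this step has no exact size: the limit of > 100000 nM in this assay, at which 1 of the 4 values shown sits.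

The compounds shown do not separate the effect of the methoxy group from that of the chain length. A 2-hydroxybutyl chain on this oxygen, or an amine in place of the methoxy group, would help to tell these apart.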